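The source may report more compounds than this note shows. Statements on the series, on what has been measured and on what is new or still open speak of the compounds shown alone.

Working notes on the shared core. Compound 1 is `COc1cccc(/C=C/C(=O)c2ccc(OC)c3c2OC(C)(C)C=C3)c1`. In a functional assay on K562 cells (Homo sapiens) for antiproliferative activity, read by MTT assay, with a stated time of 24 h (a higher number here means a weaker inhibitor, a lower number a stronger inhibitor), compound 1 reports only a limit, > 10000 nM. Compound 2, `COc1ccc(C(=O)/C=C/c2ccsc2)c2c1C=CC(C)(C)O2`, also reports a limit in this assay, > 10000 nM. Compound 3 is `COc1ccc(C(=O)/C=C/c2ccc(Cl)c(Cl)c2)c2c1C=CC(C)(C)O2`, and in this assay compound 3 gives 9030 nM. Compound 1 therefore stands at the limit rather than at a number; (the limit of > 10000 nM in this assay, at which 2 of the 3 values shown sit). Against compound 2 the step is unreadable: a step that the two limits leave unreadable from compound 1 to compound 2. Against compound 3 only a floor is known: an at least 1.1-fold lower number from compound 1 to compound 3 (0.04 log units; that floor lies within the scatter), and likewise an at least 1.1-fold lower number from compound 2 to compound 3 (0.04 log units; that floor lies within the scatter).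

Compound 4 is `COc1ccc(C(=O)/C=C/c2cc(Cl)ccc2O)c2c1C=CC(C)(C)O2`. The change from compound 1 is 5-chloro-2-hydroxyphenyl in place of 3-methoxyphenyl on a double-bonded chain carbon bound to a double-bonded chain carbon. Within the data shown here, the measured step that bears on it is the one from compound 1 to compound 3, an at least 1.1-fold lower number from compound 1 to compound 3 (0.04 log units; that floor lies within the scatter), whose entering group likewise carries chlorine and which reaches only a floor lying within the scatter. No step beyond the scatter is therefore expected in this assay, with at most a slight move toward a lower number. Compound 4 is expected to give 8000 nM, in the range 3000 nM to 30000 nM. The expected step is an at least 1.2-fold lower number from compound 1 to compound 4 (0.09 log units; that floor lies within the scatter).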

Compound 4, half-maximal inhibitory concentration: 5510 nM
Compound 4: middle estimate off by 1.5-fold (0.16 log units), on the high side, and the stated range covers the measured number.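

In this assay, 5-chloro-2-hydroxyphenyl is the second group at this place on the chain to give a number rather than a limit, and the first of those to carry a hydrogen-bond donor. Against 3,4-dichlorophenyl the change gives a 1.6-fold lower number from compound 3 to compound 4 (0.21 log units; within the scatter), so compound 3 and compound 4 are not separated. Against the other two groups, only an at least 1.8-fold lower number from compound 1 to compound 4 (0.25 log units; that floor lies within the scatter) and an at least 1.8-fold lower number from compound 2 to compound 4 (0.25 log units; that floor lies within the scatter) can be read, and the true size of each step stays unknown because compound 1 and compound 2 stand at a limit: the limit of > 10000 nM in this assay, at which 2 of the 4 values shown sit.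

The compounds shown do not separate the contribution of the hydroxy group from that of the chlorine within 5-chloro-2-hydroxyphenyl. Going by these compounds, how an aminophenyl or a carboxylic acid on the phenyl ring would read at this place in this assay also remains open.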